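The source may report more compounds than this note shows. Statements on the series, on what has been measured and on what is new or still open speak of the compounds shown alone.

Compound 1 `O=C(Nc1ccc(Oc2ccnc3[nH]ccc23)cc1)c1cc2cccnc2n(-c2ccc(Br)cc2)c1=O` gives 280 nM in a functional assay on A549 cells (Homo sapiens) for antiproliferative activity, read by MTT assay, with a stated time of 72 h; a lower number here means a stronger inhibitor, a higher number a weaker inhibitor.
Compound 2 `O=C(Nc1ccc(Oc2ccnc3[nH]ccc23)c(F)c1)c1cc2cccnc2n(-c2ccc(C(F)(F)F)cc2Cl)c1=O` gives 1020 nM.
Compound 3 `Cn1ccc2c(Oc3ccc(NC(=O)c4cc5cccnc5n(-c5ccc(Br)cc5)c4=O)cc3)ccnc21` gives 680 nM.

In this assay compound 3 stands second highest of the three numbers; the step of a 2.4-fold higher number from compound 1 to compound 3 (0.39 log units; beyond the scatter) lies beyond the scatter, whereas compound 2 sits within the scatter of compound 3. Compound 4 `Cn1ccc2c(Oc3ccc(NC(=O)c4cc5cccnc5n(-c5ccc(C(F)(F)F)cc5Cl)c4=O)cc3)ccnc21` differs from compound 3 by 2-chloro-4-(trifluoromethyl)phenyl in place of 4-bromophenyl on an aromatic nitrogen. Among the measured compounds shown here, no measured step isolates this change. Compound 1 and compound 2 differ in this aryl group and in a further place, and their two values show the compound bearing 2-chloro-4-(trifluoromethyl)phenyl with the higher number. On that basis compound 4 is expected to show a modest rise, a 1.8-fold higher number from compound 3 to compound 4 (0.25 log units; within the scatter), in this assay. The estimate for compound 4 is 1200 nM, with a range from 500 nM to 3000 nM.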

Compound 4, half-maximal inhibitory concentration: 8250 nM
Compound 4: the middle estimate sits 6.9-fold (0.84 log units) below what was measured; the whole stated range lies below it.
By their numbers in this assay, from the lowest: compound 1; then compounds 3 and 2 (each within the scatter of the next); then compound 4.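

Among the compounds shown here, on the aromatic nitrogen of the shared core, the aryl group alone proves able to move the result strongly in this assay, a point no earlier pair could isolate. Placing 2-chloro-4-(trifluoromethyl)phenyl there in place of 4-bromophenyl gives a 12-fold higher number from compound 3 to compound 4 (1.08 log units; beyond the scatter), a large loss of antiproliferative activity. Nothing available accounts for the size of this step.

The compounds shown leave open whether the chlorine or the trifluoromethyl group carries this step, as neither appears alone on the ring. They also leave open how an aryl group bearing an amine or a carboxylic acid would read at this position.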